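From Hydroxy to Bromo on the Benzyl Group

The source may report more compounds than this note shows. Statements on the series, on what has been measured and on what is new or still open speak of the compounds shown alone.

Of the compounds shown here, two sharing one core have been tested in a functional assay on MT4 cells (Homo sapiens) for cytotoxicity, read by MTT assay; on this read-out lower numbers stand for higher toxicity in this test and higher numbers for lower toxicity in this test. Compound 1 `COc1ccc(CSc2nc(O)c(C)c(Cc3c(Cl)cccc3Cl)n2)cc1OC` gives > 55000 nM, and this value is a limit of the assay, not a number. Among the measured compounds shown here, compound 2 `Cc1c(O)nc(SCc2ccc(O)cc2)nc1Cc1c(Cl)cccc1Cl` gives 41000 nM, the only true number available in this assay, so its standing cannot be judged against a second number.

Compound 3 `Cc1c(O)nc(SCc2ccc(Br)cc2)nc1Cc1c(Cl)cccc1Cl` keeps the core of compound 2 and carries bromo in place of hydroxy on an aromatic carbon, turning 4-hydroxybenzyl into 4-bromobenzyl: bromo in place of hydroxy on an aromatic carbon. The change sits on a six-membered aromatic ring of carbon only, para to a large group. For the measured compounds named here, no measured pair differing in one place is available to size this change. The expectation therefore starts from compound 2 at 41000 nM and allows only a small move toward lower numbers, not clearly beyond the usual scatter. The estimated step of a 1.5-fold lower number from compound 2 to compound 3 (0.17 log units; within the scatter) reflects this caution. For compound 3 the expected value is 28000 nM, with an estimated range of 10000 nM to 55000 nM.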

Compound 3, half-maximal cytotoxic concentration: 13000 nM
Beside the measured number, compound 3's estimate is 2.2-fold (0.33 log units) above it; low and high end bracket the measured number.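

Replacing hydroxy with bromo on an aromatic carbon of the six-membered aromatic ring, para to a large group, gives a 3.2-fold lower number from compound 2 to compound 3 (0.50 log units; beyond the scatter) in this assay, so this position is not silent in this test. Among the compounds shown here, a lower number here stands for higher toxicity in this test, and this pair supplies the first measured step between two compounds that differ in one place, showing that a single heavy atom exchanged at this position is enough to move the read-out beyond the usual scatter. Compound 1 gives only a limit of the assay, so it adds no second number to set against this step: the limit of > 55000 nM in this assay, at which 1 of the 3 values shown sits.

This single pair cannot tell whether the step comes from the arrival of bromo or from the departure of hydroxy, and it says nothing about how far the trend would extend to other groups. A chloro group, an amine or a carboxylic acid at the same position on the benzyl ring would be needed to separate these readings, and the shared core would have to be varied to show whether the step holds elsewhere.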